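This account rests on a few compounds, and the source may have more. Where it says the series, first, only, none or still open, it means among the compounds named here.

Working notes on the series. For the measured compounds named here, compound 1 `COc1cc2c(Oc3ccc(NC(=O)c4cc(-c5ccc(F)cc5)ccn4)cc3F)ccnc2cc1OCCCN1CCN(C)CC1` gives 1460 nM in a functional assay on HT-29 cells (Homo sapiens) for cytotoxicity, read by MTT assay, with a stated time of 72 h (on this read-out higher numbers stand for weaker inhibition and lower numbers for stronger inhibition), the highest number of the three measured so far. Compound 2 `COc1cc2c(Oc3ccc(NC(=O)c4cc(-c5ccccc5F)ccn4)cc3F)ccnc2cc1OCCCN1CCN(C)CC1` gives 220 nM and compound 3 `COc1ccc(-c2ccnc(C(=O)Nc3ccc(Oc4ccnc5cc(OCCCN6CCN(C)CC6)c(OC)cc45)c(F)c3)c2)c(OC)c1` gives 420 nM; the measured steps are a 6.6-fold lower number from compound 1 to compound 2 (0.82 log units; beyond the scatter), a 3.5-fold lower number from compound 1 to compound 3 (0.54 log units; beyond the scatter) and a 1.9-fold higher number from compound 2 to compound 3 (0.28 log units; within the scatter), each of them a change of the aryl group on the aromatic carbon. Compound 4 `COc1cc2c(Oc3ccc(NC(=O)c4cc(-c5ccc(F)cc5)ccn4)cc3F)ccnc2cc1OCCCN1CCCC1` differs from compound 1 elsewhere: pyrrolidin-1-yl in place of 4-methylpiperazin-1-yl on a saturated chain carbon, three bonds along the chain from an oxygen on an aromatic ring. Going by the values given here, none of the measured steps touches this chain end, which is the same in compounds 1, 2 and 3, so they give no guide to direction or size here. No step beyond the scatter is therefore expected, with wide uncertainty: a 1.0-fold lower number from compound 1 to compound 4 (0.02 log units; within the scatter). Compound 4 is accordingly estimated at 1400 nM, within a range from 400 nM to 5000 nM.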

Compound 4, half-maximal inhibitory concentration: 430 nM
Compound 4: the middle estimate sits 3.3-fold (0.51 log units) above what was measured; the range from low to high includes it.
By their numbers in this assay, from the lowest: compounds 2, 3 and 4 (each within the scatter of the next); then compound 1.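

For the compounds shown here, this is the first step at the chain end, and pyrrolidin-1-yl in place of 4-methylpiperazin-1-yl gives a 3.4-fold lower number from compound 1 to compound 4 (0.53 log units; beyond the scatter) with the 4-fluorophenyl group held constant, so the number responds at this position as well as at the aryl group. The step changes ring size and hetero atom count together, and the pair does not separate the two. No available measurement bears on the cause of this step. Open, on these data alone, is whether the step carries over to the 2-fluorophenyl group of compound 2, and how piperidin-1-yl or morpholin-4-yl would compare at the same chain end.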